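Swapping the aryl ketone on a nucleoside-linked benzophenone ester

The source may report more compounds than this note shows. Statements on the series, on what has been measured and on what is new or still open speak of the compounds shown alone.

Measured compounds:
Compound 1 `COc1cccc(C(=O)c2ccc(OC)c(OC(=O)CCC(=O)OC[C@@H]3C=C[C@H](n4cc(C)c(=O)[nH]c4=O)O3)c2)c1` gives 1580 nM in a functional assay on HeLa cells (Homo sapiens) for antiproliferative activity, read by MTT assay, with a stated time of 48 h; a lower number here means a stronger inhibitor, a higher number a weaker inhibitor.
Compound 2 `COc1ccc(C(=O)c2ccc([N+](=O)[O-])cc2)cc1OCC(=O)OC[C@@H]1C=C[C@H](n2cc(C)c(=O)[nH]c2=O)O1` gives 50200 nM in this assay.
Compound 3 `COc1ccc(C(=O)c2ccccc2Cl)cc1OCC(=O)OC[C@@H]1C=C[C@H](n2cc(C)c(=O)[nH]c2=O)O1` gives 45800 nM in this assay.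

Compound 1 stands lowest of the three numbers in this assay; the nearest of the others is compound 3 and the furthest compound 2, both of them far beyond the scatter from compound 1. Compounds 2 and 3 differ from compound 1 in more than one place, so their values can only be set beside it, not read as a single step.

Compound 4 `COc1ccc(C(=O)c2ccc(F)cc2)cc1OC(=O)CCC(=O)OC[C@@H]1C=C[C@H](n2cc(C)c(=O)[nH]c2=O)O1` differs from compound 1 in one place: 4-fluorophenyl in place of 3-methoxyphenyl on a carbonyl carbon. Going by the values given here, the only measured step of a similar kind is the aryl swap on the carbonyl carbon in a 1.1-fold lower number from compound 2 to compound 3 (0.04 log units; within the scatter), which left the number essentially where it was. Because a 1.1-fold lower number from compound 2 to compound 3 (0.04 log units; within the scatter) stayed within the scatter, a step of at most modest size is expected from compound 1 to compound 4, with no clear direction. The estimate for compound 4 in this assay is therefore 2500 nM, within a range of 800 nM to 8000 nM, which corresponds to an expected step of a 1.6-fold higher number from compound 1 to compound 4 (0.20 log units; within the scatter).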

Compound 4, half-maximal inhibitory concentration: 17800 nM
Estimate against measurement, compound 4: 7.1-fold (0.85 log units) below, and the stated range ends below it.
By their numbers in this assay, from the lowest: compound 1; then compound 4; then compounds 3 and 2 (each within the scatter of the next).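

In this assay, putting 4-fluorophenyl in place of 3-methoxyphenyl on a carbonyl carbon gives an 11-fold higher number from compound 1 to compound 4 (1.05 log units; beyond the scatter) and so shows that, in the core of compound 1, the number responds strongly to the aryl group at this position. Going by these compounds alone, the only earlier aryl swap, a 1.1-fold lower number from compound 2 to compound 3 (0.04 log units; within the scatter) and within the scatter, gave no sign of this, but it involved different aryl groups on a different chain, so its flat result does not carry over to compound 1. Nothing shown gives a reason for the large step.

The step removes the methoxy group and introduces the fluorine in a single change, so it remains open which of the two accounts for the higher number. Neither an unsubstituted phenyl nor a 3-fluorophenyl group stands among the compounds shown, and either one on the same carbonyl carbon would help to separate the two.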